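A few compounds are considered here, and "the series" means these few. Any claim that something is new, unique, unknown or untested is made for them only; others in the source may bear on it.

Working notes on the series in a physicochemical assay for solubility, using the shake flask method, measured as kinetic solubility, with a stated time of 20 h, at pH 2; a higher number here means a more soluble compound, a lower number a less soluble compound.

Three compounds carry the shared core with differing aryl groups at both ends. Compound 1, `FC(F)(F)Oc1ccc(-c2nc3cnc(Nc4ccccn4)cc3[nH]2)cc1`, gives 26000 nM in this assay. Compound 2, `FC(F)(F)c1cccc(-c2nc3cnc(Nc4ccncn4)cc3[nH]2)c1`, gives 200000 nM, and compound 3, `Fc1ccnc(Nc2cc3[nH]c(-c4ccc(F)c(F)c4)nc3cn2)c1`, gives 166000 nM. Compound 2 has the highest of the three numbers; its gap to compound 3 is within the scatter, so no order between those two can be read, while its gap to compound 1 is beyond the scatter.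

Compound 4, `NC(=O)c1ccc(Nc2cc3[nH]c(-c4cccc(C(F)(F)F)c4)nc3cn2)nc1`, has not yet been measured in this assay. It differs from compound 2 in one place: 5-carbamoylpyridin-2-yl in place of pyrimidin-4-yl on a nitrogen on an aromatic ring. For the measured compounds named here, no measured pair in the set isolates a change of this kind, so nothing in the data fixes its direction. The step from compound 2 to compound 4 is expected to be small, if any, and not beyond the scatter, as a 1.7-fold lower number from compound 2 to compound 4 (0.22 log units; within the scatter). Compound 4 is estimated at 120000 nM in this assay, with a range from 40000 nM to 300000 nM.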

Compound 4, solubility: < 5000 nM
Compound 4: only a limit was reported; the forecaster's own chance of this, stated with the estimate: 10%; middle value at least 24-fold (1.38 log units) away from the limit.
By their numbers in this assay, from the lowest: compound 1; then compounds 3 and 2 (each within the scatter of the next). At a limit, below all of these: compound 4.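

In this assay, for the compounds shown here, this is the first step that isolates a single place, the aromatic group on the nitrogen on an aromatic ring: an at least 40-fold lower number from compound 2 to compound 4 (1.60 log units; beyond the scatter). The trifluoromethyl-bearing aryl end stays the same across this pair, so this one exchange is enough to give a step beyond the scatter, with 5-carbamoylpyridin-2-yl bringing one hydrogen-bond donor that pyrimidin-4-yl lacks. The reading for compound 4 is a limit and not a number, so the step gives only a bound on the change: the limit of < 5000 nM in this assay, at which 1 of the 4 values shown sits.

The compounds shown do not separate the change of ring from the addition of the carbamoyl group, and the full size of the step stays unknown. On these data alone, whether an amine or a carboxylic acid in place of the carbamoyl group would give a similar step also remains open.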